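Thiophene to furan exchange on the aryl substituent

This account rests on a few compounds, and the source may have more. Where it says the series, first, only, none or still open, it means among the compounds named here.

Of the compounds shown here, three of the shared core have been read in an assay on isolated protein for agonist activity at Bile acid receptor (Homo sapiens), read by AlphaScreen, with a stated time of 30 min; on this read-out higher numbers stand for larger maximal responses and lower numbers for smaller maximal responses. Compound 1 `Cc1ccc(-n2nc(C)c3c2NC(=O)[C@H](C)S[C@@H]3c2ccc(Oc3ccccc3)cc2)cc1` gives 11% in this assay. Compound 2 `COc1cccc(-c2ccc([C@H]3S[C@@H](C)C(=O)Nc4c3c(C)nn4-c3ccccc3C)cc2)c1` gives 41%. Compound 3 `Cc1ccccc1-n1nc(C)c2c1NC(=O)[C@H](C)S[C@@H]2c1ccc(-c2ccsc2)cc1` gives 68%, the highest of the three numbers; its gaps to compound 2 and to compound 1 both lie beyond the scatter.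

For the measured compounds named here, the only measured step between two compounds that differ in one place is a number 27 percentage points higher from compound 2 to compound 3 (beyond the scatter). It replaces one aromatic group by another on an aromatic carbon and lies beyond the scatter.

Compound 4 `Cc1ccccc1-n1nc(C)c2c1NC(=O)[C@H](C)S[C@@H]2c1ccc(-c2ccco2)cc1` is not yet measured. The change from compound 3 is furan-2-yl in place of thiophen-3-yl on an aromatic carbon. Both groups are five-membered aromatic rings with one hetero atom and one hydrogen-bond acceptor. Going by the values given here, no measured step exchanges one such ring for another, so the step from compound 2 to compound 3 bears on it only by showing that this assay responds to a change of the group at that place. A step of the same size is not expected; a small drift within the scatter is the expectation.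

For compound 4 the estimated value in this assay is 58%, with a range from 38% to 78%. The expected step is a number 10 percentage points lower from compound 3 to compound 4 (within the scatter), slightly downward but within the scatter.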

Compound 4, largest response reached (reported as efficacy), in percent of the reference or control that the assay uses: 32%
For compound 4 the middle estimate is 26 percentage points above the measured one; measured number below the stated range.
By their numbers in this assay, from the lowest: compound 1; then compounds 4 and 2 (each within the scatter of the next); then compound 3.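

In this assay, the two groups exchanged are alike in every count, each being a five-membered aromatic ring with 1 hetero atom and 1 hydrogen-bond acceptor, yet the exchange is a large step (a number 36 percentage points lower from compound 3 to compound 4 (beyond the scatter)). This place on the six-membered aromatic ring, para to a large group, therefore separates groups that these counts do not, and the gain seen with thiophen-3-yl does not extend to five-membered aromatic rings with one hetero atom in general, with compound 4 going against such a reading. Furan-2-yl and 3-methoxyphenyl cannot be told apart here (a number 9 percentage points lower from compound 2 to compound 4 (within the scatter)), although they differ in ring size, and nothing on hand accounts for the gap between the two five-membered rings.

From the compounds shown here alone, the hetero atom and the point of attachment change together between compound 3 and compound 4, so it stays open which of the two matters; thiophen-2-yl and furan-3-yl at this place would separate them. Also open, going by these compounds, is where a pyridyl ring, an amine or a carboxylic acid at the same place would fall relative to compound 3 and compound 4.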